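The source may report more compounds than this note shows. Statements on the series, on what has been measured and on what is new or still open speak of the compounds shown alone.

Measured in a functional assay on MCF7 cells (Homo sapiens) for inhibition, read by MTT assay; a higher number here means a weaker inhibitor of growth, a lower number a stronger inhibitor of growth:
compound 1, `COc1cc2oc(-c3cccc(NC(=O)c4ccc(Br)cc4)c3)cc(=O)c2c(OC)c1OC`, gives 9650 nM
compound 2, `COc1cc2oc(-c3cccc(NC(=O)c4cccc(Br)c4)c3)cc(=O)c2c(OC)c1OC`, gives 6340 nM
compound 3, `COc1cc2oc(-c3cccc(NC(=O)c4ccc(Cl)cc4)c3)cc(=O)c2c(OC)c1OC`, gives 8780 nM

Compound 2 stands at the lowest of the three numbers, but its gaps to the others, a 1.4-fold higher number from compound 2 to compound 3 (0.14 log units; within the scatter) and a 1.5-fold lower number from compound 1 to compound 2 (0.18 log units; within the scatter), both sit within the scatter, so the three cannot be told apart. The halogen exchange from compound 1 to compound 3 is likewise flat: a 1.1-fold lower number from compound 1 to compound 3 (0.04 log units; within the scatter). Compound 4, `COc1ccc(C(=O)Nc2cccc(-c3cc(=O)c4c(OC)c(OC)c(OC)cc4o3)c2)cc1`, differs from compound 2 by 4-methoxyphenyl in place of 3-bromophenyl on a carbonyl carbon. Going by the values given here, no measured step touches a methoxy group on this ring; the steps show only that exchanging or moving a halogen there gives steps within the scatter. The step of a 1.3-fold higher number from compound 2 to compound 4 (0.10 log units; within the scatter) is therefore expected to stay within the scatter, with a wide range for the untested group. Compound 4 is estimated at 8000 nM, between 3000 nM and 25000 nM.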

Compound 4, concentration for 50% growth inhibition: 6870 nM
Estimate against measurement, compound 4: 1.2-fold (0.07 log units) above; measured number inside the range.
By their numbers in this assay, from the lowest: compounds 2, 4, 3 and 1 (each within the scatter of the next).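

On the carbonyl carbon, 4-methoxyphenyl in place of 3-bromophenyl gives a 1.1-fold higher number from compound 2 to compound 4 (0.03 log units; within the scatter), so a group that is not a halogen also stays within the scatter at this place. Methoxy in place of chloro gives a 1.3-fold lower number from compound 3 to compound 4 (0.11 log units; within the scatter), and methoxy in place of bromo gives a 1.4-fold lower number from compound 1 to compound 4 (0.15 log units; within the scatter), leaving all four compounds indistinguishable. No evidence is available that bears on these flat steps. Still open, going by these compounds, is whether an amine, a carboxylic acid or a longer chain on this ring would give a step beyond the scatter.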